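Compound 1 to Compound 3: a Ring Group Gives Way

A few compounds are considered here, and "the series" means these few. Any claim that something is new, unique, unknown or untested is made for them only; others in the source may bear on it.

Going by the values given here, compound 1 `Cc1n[nH]cc1-c1cccc2c1CCC2c1ncc[nH]1` gives 91% in a functional assay on CHO cells for agonist activity at Alpha-1A adrenergic receptor (Homo sapiens), read by FLIPR and calcium flux (a higher number here means a larger maximal response, a lower number a smaller maximal response), the higher of the two numbers measured so far. Compound 2 `CNC(=O)c1cccc2c1CCC2c1ncc[nH]1` gives 59%, and the step of a number 32 percentage points lower from compound 1 to compound 2 (beyond the scatter) came from methylcarbamoyl in place of 3-methyl-1H-pyrazol-4-yl on an aromatic carbon. Compound 3 `CCS(=O)(=O)Nc1cccc2c1CCC2c1ncc[nH]1` differs from compound 1 in a similar way: (ethylsulfonyl)amino in place of 3-methyl-1H-pyrazol-4-yl on an aromatic carbon. Among the compounds with values here, only that one measured step bears on this exchange of the same ring group for a small non-ring group, and it was large and downward, so a comparable drop is expected, a number 31 percentage points lower from compound 1 to compound 3 (beyond the scatter). Compound 3 is therefore estimated to reach 60%, within 40% to 85%.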

Compound 3, largest response reached (Emax), in percent of the reference or control that the assay uses: 86%
For compound 3 the middle estimate is 26 percentage points below the measured one, outside the stated range (above it).
By their numbers in this assay, from the lowest: compound 2; then compounds 3 and 1 (each within the scatter of the next).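

The ring is not needed for a large response at this aromatic carbon: (ethylsulfonyl)amino in its place gives a number 5 percentage points lower from compound 1 to compound 3 (within the scatter) in this assay and so stays level with 3-methyl-1H-pyrazol-4-yl. The loss seen earlier is therefore not shared by every non-ring group, since the other comparison gives a number 27 percentage points higher from compound 2 to compound 3 (beyond the scatter) when (ethylsulfonyl)amino replaces methylcarbamoyl. No available evidence explains why these two non-ring groups differ.

From the compounds shown here alone, whether a plain amine, a carboxylic acid or a longer chain such as butylsulfonylamino would hold the response at this carbon remains open. The compounds shown also leave open how much of the (ethylsulfonyl)amino group is required.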